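The source may report more compounds than this note shows. Statements on the series, on what has been measured and on what is new or still open speak of the compounds shown alone.

In a functional assay on MCF7 cells (Homo sapiens) for inhibition (a lower number here means a stronger inhibitor, a higher number a weaker inhibitor), compound 1 `CCCCCCCC[C@@]1(C)SC(=O)C=C1OCC(=O)OCC` gives 10.8 ug/mL, and compound 2 `CCCCCCCC[C@@]1(C)SC(=O)C=C1OCC(=O)O` gives 13.8 ug/mL. Within the data shown here, these two values lie within the scatter of each other, so compound 2 holds no distinct rank on the numbers so far. Compound 3 `C=CCNC(=O)COC1=CC(=O)S[C@]1(C)CCCCCCCC` keeps the shared core and carries allylamino in place of hydroxy on a carbonyl carbon. Among the measured compounds shown here, only one measured step bears on this change. Hydrogen in place of ethyl on an oxygen next to a carbonyl group gave a 1.3-fold higher number from compound 1 to compound 2 (0.11 log units; within the scatter). For the measured compounds named here, that step alters a different group, and no compound with allylamino has a measured value, so the guidance is thin. On this evidence, no shift beyond the scatter is expected in this assay, and the expected step is a 1.2-fold lower number from compound 2 to compound 3 (0.06 log units; within the scatter). For compound 3 the estimated value is 12 ug/mL, with an expected range of 5 ug/mL to 30 ug/mL.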

Compound 3, half-maximal inhibitory concentration: > 50 ug/mL
Compound 3: only a limit was reported; the forecaster's own chance of this, stated with the estimate: 5%; at least 4.1-fold (0.61 log units) between middle value and limit.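

In this assay, the group on the carbonyl carbon turns out not to be indifferent: allylamino in place of hydroxy gives an at least 3.6-fold higher number from compound 2 to compound 3 (0.55 log units; beyond the scatter), and allylamino in place of ethoxy gives an at least 4.6-fold higher number from compound 1 to compound 3 (0.66 log units; beyond the scatter). The earlier pair had shown only that hydroxy and ethoxy at this place lie within the scatter of each other, so this is the first change here with a step beyond the scatter. The reading for compound 3 is a limit of the assay and not a number: the limit of > 50 ug/mL in this assay, at which 1 of the 3 values shown sits.

From the compounds shown here alone, how far compound 3 lies past that limit remains open, so the true size of both steps is unknown. Also open, going by these compounds, is whether the nitrogen or the allyl part goes with the shift, a question that a plain amino or a propylamino group on this carbonyl carbon would bear on.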